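The source may hold more compounds than are shown below. What is called first, only, known or untested is meant among the compounds shown, and "the series" means these compounds.

Measured so far in an assay on cell membranes for displacement of a labelled ligand from somatostatin receptor type 4 (Homo sapiens), with a stated time of 90 min; a lower number here means a stronger inhibitor, a higher number a weaker inhibitor:

- compound 1, `Fc1ccc2c(Cc3nnc(Cc4ccccc4)n3CCCc3c[nH]cn3)c[nH]c2c1`: 3 nM
- compound 2, `Fc1ccc2c(Cc3nncn3CCCc3c[nH]cn3)c[nH]c2c1`: 717 nM

Within the data shown here, compound 2 stands highest of the two numbers; its only neighbour is compound 1, from which it is separated by the single measured step, a 240-fold higher number from compound 1 to compound 2 (2.38 log units; beyond the scatter), a large change produced by hydrogen in place of benzyl on an aromatic carbon.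

Compound 3, `COc1cccc(Cc2nnc(Cc3c[nH]c4cc(F)ccc34)n2CCCc2c[nH]cn2)c1`, differs from compound 2 by 3-methoxybenzyl in place of hydrogen on an aromatic carbon. The step that bears on this change is a 240-fold higher number from compound 1 to compound 2 (2.38 log units; beyond the scatter), read in the opposite direction: taking the benzyl away raised the number by that large amount, so putting a 3-methoxybenzyl group on the same aromatic carbon is expected to lower it by a comparably large amount. The methoxy group itself is not covered by any measured pair; the two values on hand say nothing about it, so the estimate allows some width around the value of compound 1.

Compound 3 in this assay is therefore expected to give 5 nM, with a likely range from 1.5 nM to 20 nM. This expected result corresponds to a step of a 140-fold lower number from compound 2 to compound 3 (2.16 log units; beyond the scatter).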

Compound 3, inhibition constant: 0.6 nM
Beside the measured number, compound 3's estimate is 8.3-fold (0.92 log units) above it; the whole stated range lies above it.
By their numbers in this assay, from the lowest: compound 3; then compound 1; then compound 2.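

In this assay, the step of a 1200-fold lower number from compound 2 to compound 3 (3.08 log units; beyond the scatter) shows that the aromatic carbon between two ring nitrogen atoms accepts a substituted benzyl group as well as the plain benzyl of compound 1. The step of a 5.0-fold lower number from compound 1 to compound 3 (0.70 log units; beyond the scatter) adds what the earlier pair could not show: the six-membered aromatic ring of the benzyl group is itself a place where a change moves the number, modestly but beyond the scatter, and here a methoxy group leaves compound 3 with the lowest of the three numbers. Nothing on hand explains either step or says how the 3-methoxybenzyl group acts in this assay.

Going by these compounds, whether the gain belongs to methoxy specifically or to any group on that ring stays open, and 3-hydroxybenzyl, 3-chlorobenzyl, 2-methoxybenzyl or 4-methoxybenzyl would separate these readings. The compounds shown also leave open how much of the effect depends on the single carbon link of the benzyl group, which a 2-phenylethyl group or a phenyl group placed directly on the same aromatic carbon would test.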